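A few compounds are considered here, and "the series" means these few. Any claim that something is new, unique, unknown or untested is made for them only; others in the source may bear on it.

Compound 1 `O=C(Nc1cccc(/C=C/C(=O)c2nc3ccccc3[nH]2)c1)c1cccc(Cl)c1` is the strongest-looking point among three measured compounds in a functional assay on 143B cells (Homo sapiens) for antiproliferative activity, read by MTT assay, with a stated time of 48 h (on this read-out lower numbers stand for stronger inhibition and higher numbers for weaker inhibition), where compound 1 gives 3370 nM. Compound 2 `O=C(/C=C/c1cccc(NC(=O)c2ccccc2Br)c1)c1nc2ccccc2[nH]1` gives 6050 nM in this assay, and compound 3 `O=C(Nc1cccc(/C=C/C(=O)c2nc3ccccc3[nH]2)c1)c1ccc(Br)cc1` gives 7310 nM. The step of a 1.8-fold higher number from compound 1 to compound 2 (0.25 log units; within the scatter) stays within the scatter, while the step of a 2.2-fold higher number from compound 1 to compound 3 (0.34 log units; beyond the scatter) goes modestly beyond it. Compound 4 `O=C(/C=C/c1cccc(NS(=O)(=O)c2ccc(Cl)cc2)c1)c1nc2ccccc2[nH]1` differs from compound 1 in one place: (4-chlorophenyl)sulfonyl in place of (3-chlorophenyl)carbonyl on a nitrogen on an aromatic ring. The measured steps change only the halogenated aryl group on the carbonyl carbon; none exchanges the carbonyl itself for a sulfonyl, so they bear on this step only loosely. Both measured steps moved to higher numbers, so a modest rise is expected here, with wide uncertainty. The step expected from this change is a 1.6-fold higher number from compound 1 to compound 4 (0.21 log units; within the scatter), and the estimated value of compound 4 in this assay is 5500 nM, within the range 1500 nM to 20000 nM.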

Compound 4, half-maximal inhibitory concentration: 7450 nM
The estimate for compound 4 lay 1.4-fold (0.13 log units) below the measured number; the measured number falls inside the stated range.
By their numbers in this assay, from the lowest: compounds 1, 2, 3 and 4 (each within the scatter of the next, the first and the last beyond it).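

Putting (4-chlorophenyl)sulfonyl on this nitrogen in place of (3-chlorophenyl)carbonyl gives a 2.2-fold higher number from compound 1 to compound 4 (0.34 log units; beyond the scatter), the first view of a link other than carbonyl here. Against the bromophenyl compounds, the change gives a 1.0-fold higher number from compound 3 to compound 4 (0.01 log units; within the scatter) and a 1.2-fold higher number from compound 2 to compound 4 (0.09 log units; within the scatter), so the sulfonyl compound sits level with both and only compound 1 stands apart from it. The chlorine's place changes along with the link, so this step cannot separate the two changes.

Nothing given here explains these numbers. Still open, from the compounds shown here alone, is whether (3-chlorophenyl)sulfonyl would match compound 1, and what an amine or a carboxylic acid in place of the halogen would do.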